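From Isopropoxycarbonyl to Ethoxycarbonyl: Adenosine Receptor Binding

The compounds below may be only part of what the source reports. "The series", "measured", "known", "first", "only" and "open" are said of these compounds alone.

Of the compounds shown here, three sharing one core have been measured in an assay on HeLa cells for displacement of a labelled ligand from adenosine receptor A3 (Homo sapiens), with a stated time of 180 min, tested at 1 uM; a higher number here means more inhibition at the concentration tested (going by the name of the read-out), a lower number less inhibition. Compound 1 `CC1=C(C(=O)OC(C)C)C(C2CCCC2)N/C(=N/C#N)N1` gives 3%. Compound 2 `CCOC(=O)C1=C(C)N/C(=N\C#N)NC1c1cccs1` gives 3%. Compound 3 `CC1=C(C(=O)OC(C)C)C(c2ccsc2)N/C(=N/C#N)N1` gives 13%, the highest of the three numbers, yet its gap to each of the other two lies within the usual scatter, so no ordering among them can be claimed.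

For the measured compounds named here, the only single-point step measured so far is a number 10 percentage points higher from compound 1 to compound 3 (within the scatter), a change of the group on a saturated ring carbon, which says nothing about the group carrying the carbonyl. Compound 4 `CCOC(=O)C1=C(C)N/C(=N\C#N)NC1c1ccsc1` differs from compound 3 in exactly that other place: hydrogen in place of methyl on a saturated chain carbon bound to an oxygen next to a carbonyl group and a saturated chain carbon, so that isopropoxycarbonyl becomes ethoxycarbonyl. Compound 2 also carries ethoxycarbonyl, but it differs from compound 3 in a second place as well, so its value is no clean guide. Going by the values given here, with no measured step bearing directly on this change, no movement beyond the scatter is expected, and the step for compound 4 is estimated as a number 5 percentage points lower from compound 3 to compound 4 (within the scatter). Compound 4 is therefore expected to give about 8%, somewhere between 0% and 25%.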

Compound 4, a percentage reported as inhibition, at one concentration (the size of the read-out at that concentration, not a potency): 23%
The estimate for compound 4 lay 15 percentage points below the measured number; the measured number falls inside the stated range.
By their numbers in this assay, from the lowest: compounds 1, 2, 3 and 4 (each within the scatter of the next, the first and the last beyond it).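

In this assay, the change from isopropoxycarbonyl to ethoxycarbonyl gives a number 10 percentage points higher from compound 3 to compound 4 (within the scatter), so this first direct reading of that change shows no shift that can be told apart from ordinary repeat variation. With ethoxycarbonyl held constant, thiophen-3-yl in place of thiophen-2-yl on a saturated ring carbon gives a number 20 percentage points higher from compound 2 to compound 4 (beyond the scatter), a modest step but the first in this set to clear the scatter, showing that the attachment point of the thiophene can shift the number. No measured evidence is available to explain this step.

From the compounds shown here alone, it remains open whether a carboxylic acid or a longer chain such as butoxycarbonyl in place of ethoxycarbonyl would shift the number beyond the scatter. Going by these compounds, it is also open whether a phenyl or furan-3-yl group in place of thiophen-3-yl would keep, lose or extend the step seen with compound 4.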